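Phenoxy acid ring substitution on the shared core

The source may hold more compounds than are shown below. What is called first, only, known or untested is meant among the compounds shown, and "the series" means these compounds.

Measured so far in an assay on HEK293 cells for positive allosteric modulation of metabotropic glutamate receptor 3 (Rattus norvegicus), read by thallium flux, with a stated time of 2.5 min; a lower number here means a smaller maximal response, a higher number a larger maximal response:
- compound 1 `Cc1c(OCCCCOc2ccc(C(=O)O)cc2F)ccc(C(=O)CC2CCCC2)c1O` gives 31.2%
- compound 2 `Cc1c(OCCCCOc2ccc(C(=O)O)cc2F)ccc(C(=O)CC(C)C)c1O` gives 67.7%
- compound 3 `COc1ccc(C(=O)O)cc1OCCCCOc1ccc(C(C)=O)c(O)c1C` gives 34.8%

Compound 1 stands lowest of the three numbers in this assay. Its nearest neighbour is compound 3, whose value sits within the scatter of compound 1, so no order between these two can be stated. Among the measured compounds shown here, the furthest is compound 2, whose value lies beyond the scatter; the one step measured so far, a number 36.5 percentage points higher from compound 1 to compound 2 (beyond the scatter), is large and concerns the group on the saturated chain carbon bound to the carbonyl carbon.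

Compound 4 `Cc1c(OCCCCOc2ccc(C(=O)O)c(Cl)c2)ccc(C(=O)CC2CCCC2)c1O` is not yet measured. Relative to compound 1 the difference is 4-carboxy-3-chlorophenyl in place of 4-carboxy-2-fluorophenyl on an oxygen on a saturated carbon. The change sits at the phenoxy acid end of the chain, which the step from compound 1 to compound 2 leaves untouched; that step therefore does not bear on it. For the measured compounds named here, no measured pair alters the carboxy-bearing ring, so the data give no direction for this change. The step to compound 4 is accordingly expected to stay within the scatter: a number 1.8 percentage points higher from compound 1 to compound 4 (within the scatter). Compound 4 is estimated at 33%, with a range from 18% to 52%.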

Compound 4, largest response reached (reported as percent of maximum), in percent of the reference or control that the assay uses: 40%
For compound 4 the middle estimate is 7 percentage points below the measured one, within the range that was stated.
By their numbers in this assay, from the lowest: compounds 1, 3 and 4 (each within the scatter of the next); then compound 2.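

In this assay the carboxy-bearing ring now has its first measured change: 4-carboxy-3-chlorophenyl in place of 4-carboxy-2-fluorophenyl on the core of compound 1 gives a step (a number 8.8 percentage points higher from compound 1 to compound 4 (within the scatter)) that does not separate the two compounds. On this cyclopentyl-bearing core, this exchange therefore gives no measurable change in maximal response, unlike the step at the other end of the molecule (a number 36.5 percentage points higher from compound 1 to compound 2 (beyond the scatter)), which lies beyond the scatter. No measurement at hand accounts for either outcome.

The exchange alters both the halogen and its numbered ring position, so this one pair cannot show whether either alteration alone would leave the response unchanged, or whether the same exchange would hold on the isopropyl-bearing core of compound 2 (67.7%). Also open, as far as these compounds go, is how the response would follow an unsubstituted 4-carboxyphenyl, a bromine on the same ring, or a tetrazole or an amide in place of the carboxylic acid.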